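The source may report more compounds than this note shows. Statements on the series, on what has been measured and on what is new or still open speak of the compounds shown alone.

Going by the values given here, compound 3 (`O=[N+]([O-])c1cc2c(O)c(-c3ccc(Cl)cc3Cl)c(O)nc2cc1Cl`) is the only member of this set with a single number in an assay on isolated protein for inhibition of fatty acid synthase (Rattus norvegicus) (on this read-out higher numbers stand for weaker inhibition and lower numbers for stronger inhibition), where compound 3 gives 443 nM. Compound 2 (`CS(=O)(=O)c1ccc2nc(O)c(-c3ccccc3)c(O)c2c1`) reaches only a limit of that assay, reported for compound 2 as > 15000 nM. For compound 1 (`N#Cc1cc(Cl)c2nc(O)c(-c3ccccc3)c(O)c2c1`) the entry in this assay is "not determined" (no result reported), so no number exists. Among the compounds with values here, with one number and one limit, no step between measured compounds can be drawn, and the limit stands at the limit of > 15000 nM in this assay, at which 1 of the 3 values shown sits.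

Compound 4 (`O=[N+]([O-])c1cc2c(O)c(-c3cc(F)cc(F)c3)c(O)nc2cc1Cl`) differs from compound 3 in one place: 3,5-difluorophenyl in place of 2,4-dichlorophenyl on an aromatic carbon. Nothing measured here tells how this assay answers such an exchange, so the expectation rests on compound 3 alone and carries a wide range. A step that is small or within the scatter seems most plausible, with weaker inhibition somewhat more likely than stronger. Compound 4 is therefore expected to give about 1200 nM in this assay, within 400 nM to 4000 nM, which means an expected step of a 2.7-fold higher number from compound 3 to compound 4 (0.43 log units; beyond the scatter).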

Compound 4, half-maximal inhibitory concentration: 172 nM
Compound 4: middle estimate off by 7.0-fold (0.84 log units), on the high side; the whole stated range lies above it.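

In this assay the exchange of 2,4-dichlorophenyl for 3,5-difluorophenyl, on the aromatic carbon ortho to two hydroxy groups, gives a 2.6-fold lower number from compound 3 to compound 4 (0.41 log units; beyond the scatter) with the rest of the structure unchanged. Going by these compounds alone, this is the first step in the set, and it shows that this position responds to a change in the aryl group and that the ring need not carry chlorine for inhibition to be kept. Nothing measured here gives a cause for this step.

As far as these compounds go, since the halogens and their places change together, it stays open which of the two matters, and a ring with a methoxy group or an amine at this position remains unexplored. Compound 2 gives only a limit of > 15000 nM and differs from this pair in more than one place, so the plain phenyl on this core also remains unanswered.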